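Side-chain change from compound 2 to compound 3

The source may hold more compounds than are shown below. What is called first, only, known or untested is meant among the compounds shown, and "the series" means these compounds.

Measured in an assay for inhibition of RAC-alpha serine/threonine-protein kinase (Homo sapiens), read by HTRF, with a stated time of 1 h; on this read-out higher numbers stand for weaker inhibition and lower numbers for stronger inhibition:
compound 1 `Cn1ncc(Cl)c1-c1cc(C(=O)NC2CNCCC2c2ccc(C(F)(F)F)cc2)oc1Cl`: 7.2 nM
compound 2 `Cn1ncc(Cl)c1-c1cc(C(=O)N[C@@H]2CN[C@H](CCN3CCC(O)CC3)C[C@H]2c2ccc(Cl)c(Cl)c2)oc1Cl`: 5.99 nM

Compound 2 shows the lower of the two numbers in this assay, but compound 1 stands within the scatter of it, so the two are not separable on these data. Compound 1 carries no substituent on the saturated ring carbon where compound 2 bears the 2-(4-hydroxypiperidin-1-yl)ethyl chain, and both give much the same number.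

Compound 3 `Cn1ncc(Cl)c1-c1cc(C(=O)N[C@@H]2CN[C@H](CC(N)=O)C[C@H]2c2ccc(Cl)c(Cl)c2)oc1Cl` differs from compound 2 by carbamoyl in place of (4-hydroxypiperidin-1-yl)methyl on a saturated chain carbon bound to a saturated ring carbon. Among the compounds with values here, no step between measured compounds covers this change. Given that compound 1 and compound 2 sit together, the shortened chain is expected to matter little, and the step of a 1.3-fold higher number from compound 2 to compound 3 (0.13 log units; within the scatter) is expected to stay within the scatter. Compound 3 is therefore estimated at 8 nM, with a range from 3 nM to 25 nM.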

Compound 3, half-maximal inhibitory concentration: 3.24 nM
Beside the measured number, compound 3's estimate is 2.5-fold (0.39 log units) above it; measured number inside the range.
By their numbers in this assay, from the lowest: compounds 3, 2 and 1 (each within the scatter of the next, the first and the last beyond it).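

In this assay, carbamoyl in place of (4-hydroxypiperidin-1-yl)methyl on a saturated chain carbon bound to a saturated ring carbon gives a 1.8-fold lower number from compound 2 to compound 3 (0.27 log units; within the scatter). The six-membered non-aromatic ring of the 2-(4-hydroxypiperidin-1-yl)ethyl chain is therefore not needed to hold a number of this size, and the much shorter carbamoylmethyl serves at this position without a separable change. Nothing measured on these compounds offers an explanation for this result.

On these data alone, whether a carboxylic acid or a primary amine in place of carbamoyl, or a longer chain ending in carbamoyl, would hold the number remains open. Also open, as far as these compounds go, is whether carbamoylmethyl adds anything over a bare ring carbon, since compound 1 also differs from compound 3 in its aryl group.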